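Five-membered heteroaryl swaps on the shared core

The source may hold more compounds than are shown below. What is called first, only, known or untested is meant among the compounds shown, and "the series" means these compounds.

Compound 1 `OC[C@H]1OC(n2cnc3c(-c4ccco4)ncnc32)[C@H](O)[C@@H]1O` and compound 2 `OC[C@H]1OC(n2cnc3c(-c4cc[nH]c4)ncnc32)[C@H](O)[C@@H]1O` share one core and differ only in the five-membered ring attached to it. In a functional assay on CCRF-CEM cells (Homo sapiens) for inhibition (on this read-out lower numbers stand for stronger inhibition and higher numbers for weaker inhibition), compound 1 gives 600 nM, and in this assay compound 2 gives 1030 nM. Among the compounds with values here, the one step measured so far, a 1.7-fold higher number from compound 1 to compound 2 (0.23 log units; within the scatter), exchanged one five-membered heteroaryl for another and stayed within the scatter. Compound 2 thus stands highest of the two numbers, with compound 1 nearest and within the scatter of it.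

Compound 3 `Cn1nccc1-c1ncnc2c1ncn2C1O[C@H](CO)[C@@H](O)[C@H]1O` carries the change (1-methyl-1H-pyrazol-5-yl in place of 1H-pyrrol-3-yl on an aromatic carbon). Within the data shown here, the only step that bears on it is the heteroaryl exchange from compound 1 to compound 2, which stayed within the scatter, so no step beyond the scatter is expected in this assay for this further exchange. For compound 3 in this assay the expected value is 1200 nM, with a range from 400 nM to 3500 nM. This expectation amounts to a step of a 1.2-fold higher number from compound 2 to compound 3 (0.07 log units; within the scatter).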

Compound 3, half-maximal inhibitory concentration: "not active" (no number reported)
No number was reported for compound 3, and the estimate cannot be compared.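

Within the data shown here, compound 3 is reported as "not active" in this assay without a number, and no step from compound 2 to compound 3 can be read. The compounds shown leave open how 1-methyl-1H-pyrazol-5-yl compares numerically with 1H-pyrrol-3-yl on the shared core. No supporting evidence bears on this result.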